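Swapping the pyrrolidine for a hydroxypiperidine on the core

This account rests on a few compounds, and the source may have more. Where it says the series, first, only, none or still open, it means among the compounds named here.

Among the compounds with values here, compound 1 `O=S(=O)(c1ccccc1)c1nc2ccccc2nc1N1CCCC1` is the only member of this small set with a number rather than a limit: in a functional assay on PC-3 cells (Homo sapiens) for cytotoxicity, read by MTT assay, with a stated time of 72 h (a higher number here means a weaker inhibitor, a lower number a stronger inhibitor), compound 1 gives 20800 nM. Compound 2 `COc1ccc(S(=O)(=O)c2nc3ccccc3nc2N2CCCC2)cc1` reaches only the limit > 50000 nM in this assay. Compound 3 `O=S(=O)(c1ccc(Br)cc1)c1nc2ccccc2nc1N1CCCC1` likewise reaches only the limit > 50000 nM, so two of three values sit at that edge, (the limit of > 50000 nM in this assay, at which 2 of the 3 values shown sit). Both measured steps change an aromatic carbon: an at least 2.4-fold higher number from compound 1 to compound 2 (0.38 log units; beyond the scatter) and an at least 2.4-fold higher number from compound 1 to compound 3 (0.38 log units; beyond the scatter), while a step that the two limits leave unreadable from compound 2 to compound 3 cannot be read. Compound 4 `O=S(=O)(c1ccccc1)c1nc2ccccc2nc1N1CCC(O)CC1` differs elsewhere: 4-hydroxypiperidin-1-yl in place of pyrrolidin-1-yl on an aromatic carbon. Within the data shown here, no measured step touches this part of the molecule, so the expectation is a step of no more than the usual scatter, a 1.2-fold higher number from compound 1 to compound 4 (0.08 log units; within the scatter). Compound 4 is therefore estimated at 25000 nM, within 9000 nM to 70000 nM.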

Compound 4, half-maximal inhibitory concentration: 4980 nM
For compound 4 the middle estimate is 5.0-fold (0.70 log units) above the measured one; the measured number lies below the stated range.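

This position on the shared core is not silent: a 4.2-fold lower number from compound 1 to compound 4 (0.62 log units; beyond the scatter) in this assay, the first change shown that lowers the number rather than raising it. The swap enlarges the ring and adds a hydroxy group in a single step, and nothing shown gives a reason for the gain.

Still open, on these data alone, is whether the larger ring or the hydroxy group carries the step, a question that plain piperidin-1-yl would help settle. Also open, as far as these compounds go, is whether methoxy or bromo on the aromatic carbon would act on compound 4 as on compound 1.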